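The source may hold more compounds than are shown below. What is called first, only, known or untested is meant among the compounds shown, and "the series" means these compounds.

Measured compounds:
- compound 1, `CCC(=O)NCCC(=O)c1cc(OC)ccc1N`: 99.4%
- compound 2, `COc1ccc(N)c(C(=O)CCNC(C)=O)c1`: 102%
- compound 3, `COc1ccc(N)c(C(=O)CCNC(=O)C2CCCCC2)c1`: 99.6%

All three were tested in a functional assay for inhibition of kynurenine 3-monooxygenase (Rattus norvegicus), tested at 1 mM; on this read-out higher numbers stand for more inhibition at the one concentration tested (going by the name of the read-out) and lower numbers for less inhibition. On that read-out compound 1 gives 99.4%, the lowest of the three numbers, but its steps to the other two are both within the scatter: a number 2.6 percentage points higher from compound 1 to compound 2 (within the scatter) and a number 0.2 percentage points higher from compound 1 to compound 3 (within the scatter). The three compounds are therefore indistinguishable here.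

Compound 4, `COc1ccc(N)c(C(=O)CCNC(=O)C2CCC2)c1`, has not yet been measured. Compared with compound 1 the change is cyclobutyl in place of ethyl on a carbonyl carbon.

Going by the values given here, two measured steps bear on this. Changing the same group from ethyl to cyclohexyl gave a number 0.2 percentage points higher from compound 1 to compound 3 (within the scatter), and from methyl to cyclohexyl gave a number 2.4 percentage points lower from compound 2 to compound 3 (within the scatter). A cyclobutyl group sits between ethyl and cyclohexyl in size, and neither the small nor the large group moved the read-out beyond the scatter. No step beyond the scatter is expected for compound 4 in this assay.

Compound 4 is therefore estimated at 99.5%, with a range from 94% to 104%, which means an expected step of a number 0.1 percentage points higher from compound 1 to compound 4 (within the scatter).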

Compound 4, a percentage reported as inhibition, at one concentration (the size of the read-out at that concentration, not a potency): 92.2%
Compound 4: the middle estimate sits 7.3 percentage points above what was measured; the whole stated range lies above it.
By their numbers in this assay, from the lowest: compounds 4, 1, 3 and 2 (each within the scatter of the next).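

In this assay the cyclobutyl compound stays with the others, with a number 7.2 percentage points lower from compound 1 to compound 4 (within the scatter) and a number 7.4 percentage points lower from compound 3 to compound 4 (within the scatter) and also a number 9.8 percentage points lower from compound 2 to compound 4 (within the scatter) in the same test. These steps are larger than any among the first three compounds, yet all remain within the scatter, so a four-membered carbon ring on this carbonyl carbon cannot be told apart from methyl, ethyl or cyclohexyl here. Nothing available explains the size of these steps.

A single concentration gives no potency, so real differences among these four compounds could remain hidden. Also open, as far as these compounds go, is how the read-out would respond if a phenyl ring, or a longer chain ending in an amine or a carboxylic acid, stood on this carbonyl carbon.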